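This account rests on a few compounds, and the source may have more. Where it says the series, first, only, none or still open, it means among the compounds named here.

Measured compounds:
compound 1 `COc1ccc2c(c1)c(CC(=O)NS(=O)(=O)c1ccccc1)c(C)n2-c1ccc(-c2ccccc2)cc1` — > 10000 nM
compound 2 `COc1ccc2c(c1)c(CC(=O)NS(=O)(=O)c1ccc(Cl)c([N+](=O)[O-])c1)c(C)n2-c1ccc(-c2ccccc2)cc1` — 720 nM

In an assay on isolated protein for binding affinity to Apoptosis regulator Bcl-2 (Homo sapiens), read by fluorescence polarization, with stated times of 30 min and 20 min (a higher number here means a weaker inhibitor, a lower number a stronger inhibitor), compound 1 gives only a limit, > 10000 nM. In this assay, within the data shown here, compound 2 gives 720 nM, the single number recorded in the pair. Among the measured compounds shown here, the step of an at least 13-fold lower number from compound 1 to compound 2 (1.14 log units; beyond the scatter) is the only measured step, and it rests on (the limit of > 10000 nM in this assay, at which 1 of the 2 values shown sits), so its true size is not known.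

Compound 3 `COc1ccc2c(c1)c(CC(=O)NS(=O)(=O)c1ccc(NC3CCCCC3)c([N+](=O)[O-])c1)c(C)n2-c1ccc(-c2ccccc2)cc1` differs from compound 2 by cyclohexylamino in place of chloro on an aromatic carbon. For the measured compounds named here, no measured step touches the group that enters; the one measured step concerns the ring that already carries the nitro group and says nothing about what replaces the chloro. The expectation for compound 3 therefore stays close to compound 2, leaning toward a stronger inhibitor, with a step of a 2.9-fold lower number from compound 2 to compound 3 (0.46 log units; beyond the scatter). Compound 3 is estimated in this assay at 250 nM, between 60 nM and 1500 nM.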

Compound 3, inhibition constant: > 10000 nM
Compound 3: no number, only a limit; the forecaster's own chance of this, stated with the estimate: 3%; at least 40-fold (1.60 log units) between middle value and limit.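

At the place ortho to a nitro group and para to a large group, cyclohexylamino does not serve in place of chloro in this assay: the change gives an at least 13-fold higher number from compound 2 to compound 3 (1.14 log units; beyond the scatter). Compound 3 gives only a limit, so the true size of this step is not known: the limit of > 10000 nM in this assay, at which 2 of the 3 values shown sit. The earlier step showed only that 4-chloro-3-nitrophenyl gives a lower number than phenyl on the sulfonyl sulfur; this step shows that keeping the nitro group is not enough once chloro gives way to cyclohexylamino.

Open, from the compounds shown here alone, is whether a smaller group at this place, such as amino, methylamino or methoxy, would stay near compound 2, or whether a longer chain ending in an amine would. Also open, going by these compounds, is how a phenyl ring carrying only chloro or only nitro would read.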